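The source may report more compounds than this note shows. Statements on the series, on what has been measured and on what is new or still open speak of the compounds shown alone.

Compound 2 `O=C(Nc1ccccc1C(F)(F)F)C1CCc2ccccc2N1`: 40400 nM
Compound 1 `O=C(Nc1cc(C(F)(F)F)cc(C(F)(F)F)c1)C1CCc2ccccc2N1C(=O)c1ccccc1Cl`: 4050 nM
Compound 3 `O=C(Nc1cc(C(F)(F)F)cc(C(F)(F)F)c1)C1CCc2ccccc2N1C(=O)c1ccc(Cl)cc1`: 2220 nM

In a functional assay on HCT-15 cells (Homo sapiens) for cytotoxicity, read by sulforhodamine B assay, with a stated time of 72 h (on this read-out lower numbers stand for stronger inhibition of growth and higher numbers for weaker inhibition of growth), compound 2 gives 40400 nM, the highest number of the three measured. Compound 4 `O=C(Nc1ccccc1C(F)(F)F)C1CCc2ccccc2N1C(=O)c1ccc(Cl)cc1` differs from compound 2 by (4-chlorophenyl)carbonyl in place of hydrogen on a nitrogen on an aromatic ring in a ring. Within the data shown here, no measured pair shows this change on its own: compound 1 and compound 3 carry such a group on the ring nitrogen, but they also bear a different aryl amide, so each differs from compound 2 in two places. Still, compound 1 at 4050 nM and compound 3 at 2220 nM both sit clearly lower than compound 2. Among the measured compounds shown here, the one clean step, a 1.8-fold lower number from compound 1 to compound 3 (0.26 log units; within the scatter), shows that the position of the chlorine hardly matters. From the compounds shown here alone, a lower number for compound 4 is therefore expected, though how much of the gap comes from the acyl group alone is unknown. Compound 4 is expected to give about 8000 nM, within 2500 nM to 25000 nM. This expected step is a 5.1-fold lower number from compound 2 to compound 4 (0.70 log units; beyond the scatter).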

Compound 4, concentration for 50% growth inhibition: 839 nM
For compound 4 the middle estimate is 9.5-fold (0.98 log units) above the measured one; the whole stated range lies above it.
By their numbers in this assay, from the lowest: compound 4; then compounds 3 and 1 (each within the scatter of the next); then compound 2.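

In this assay, among these compounds, the change on this nitrogen can be read alone for the first time, as a 48-fold lower number from compound 2 to compound 4 (1.68 log units; beyond the scatter). Among the compounds shown here, with the aryl amide held the same, replacing the hydrogen with (4-chlorophenyl)carbonyl is enough for a large gain in growth inhibition, whereas the earlier comparisons with compound 2 changed two places at once. Nothing measured here explains why this step is so large. The compounds shown leave open how much depends on the chlorophenyl ring and how much on the carbonyl. An acetyl group or a longer alkyl chain on this nitrogen would help separate the two.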